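Removing a Methyl From an Aryl Ether: Expected Cytotoxicity

The compounds below may be only part of what the source reports. "The series", "measured", "known", "first", "only" and "open" are said of these compounds alone.

Measured compounds:
compound 1, `Cc1cc(O)cc(-c2nn(CC#N)cc2-c2ccnc(-c3ccc(Oc4ccccc4)cc3)c2)c1`: 41400 nM
compound 2, `COc1cc(C)cc(-c2nn(CC#N)cc2-c2ccnc(-c3ccc(N(C)C)cc3)c2)c1`: > 100000 nM

Of the compounds shown here, two have so far been tested in a functional assay on SF-268 cells (Homo sapiens) for inhibition, read by sulforhodamine B assay, with a stated time of 48 h; on this read-out higher numbers stand for lower toxicity in this test and lower numbers for higher toxicity in this test. Compound 1 gives 41400 nM. For compound 2 only a limit is reported, > 100000 nM, which is not a number but the edge of what this test can read. Compound 2 therefore stands at the less toxic end of the numbers shown; this is the situation described by the limit of > 100000 nM in this assay, at which 1 of the 2 values shown sits.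

Compound 3, `Cc1cc(O)cc(-c2nn(CC#N)cc2-c2ccnc(-c3ccc(N(C)C)cc3)c2)c1`, differs from compound 2 in a single place: hydrogen in place of methyl on an oxygen on an aromatic ring, in words hydrogen in place of methyl on an oxygen on an aromatic ring. Among the measured compounds shown here, no pair among the measured compounds shows this change by itself, so the size of the step cannot be read from the data. A step of no more than the usual scatter is expected, with a slight lean toward a lower number, since compound 1, which carries the same hydroxy group, gives 41400 nM.

Compound 3 is expected to give about 70000 nM, in the range 25000 nM to 150000 nM. The estimated step of an at least 1.4-fold lower number from compound 2 to compound 3 (0.15 log units; that floor lies within the scatter) is an expectation, not a measurement.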

Compound 3, concentration lethal to 50% of the cells: 77900 nM
Beside the measured number, compound 3's estimate is 1.1-fold (0.05 log units) below it; the measured number falls inside the stated range.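

Measured in this assay the change from methoxy to hydroxy now reads as an at least 1.2-fold lower number from compound 2 to compound 3 (0.10 log units; that floor lies within the scatter) and is no longer only an estimate. The hydroxy compounds can also now be set side by side: swapping phenoxy for dimethylamino on an aromatic carbon gives a 1.9-fold higher number from compound 1 to compound 3 (0.27 log units; within the scatter) and so, with the hydroxy group held constant, no order between these two compounds can be claimed from this test. The first figure remains only a floor, and the real step could be larger, because compound 2 has a limit rather than a number: the limit of > 100000 nM in this assay, at which 1 of the 3 values shown sits.

The compounds shown carry only hydrogen or methyl on this oxygen, so it stays open whether a longer chain such as ethyl on the oxygen, or an amine or a carboxylic acid in place of the hydroxy group, would change the reading in this assay by more than the usual scatter. Also open, from the compounds shown here alone, is how the methoxy to hydroxy change reads when phenoxy rather than dimethylamino sits on the rest of the molecule, where a version of compound 1 carrying methoxy would give a direct comparison.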